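The source may report more compounds than this note shows. Statements on the series, on what has been measured and on what is new or still open speak of the compounds shown alone.

In an assay on isolated protein for displacement of a labelled ligand from metabotropic glutamate receptor 5 (Homo sapiens), with a stated time of 60 min, tested at 1 uM (a lower number here means less inhibition, a higher number more inhibition at the concentration tested (going by the name of the read-out)), the measured compounds stand as follows:
compound 1 `CC1CCN(c2c(S(=O)(=O)c3ccccc3)cnc3ccc(Cl)cc23)CC1` gives 59%
compound 2 `COc1cccc(S(=O)(=O)c2cnc3ccc(Cl)cc3c2N2CCC(C)CC2)c1` gives 87%
compound 3 `Cc1cc(C)cc(S(=O)(=O)c2cnc3ccc(C)cc3c2N2CCC(C)CC2)c1` gives 80%

Compound 3 stands second highest of the three in this assay; its nearest neighbour is compound 2, which lies within the scatter of it, while compound 1 lies beyond the scatter below it. Compound 4 `Cc1cc(C)cc(S(=O)(=O)c2cnc3ccc(Cl)cc3c2N2CCC(C)CC2)c1` differs from compound 3 by a single change: chloro in place of methyl on an aromatic carbon. Within the data shown here, the only measured step, a number 28 percentage points higher from compound 1 to compound 2 (beyond the scatter), concerns a different part of the molecule and does not bear on this change. Compound 2, which carries chloro on the core, and compound 3, which carries methyl on the core, also differ elsewhere, so their two values alone cannot separate the two groups. The expected step is therefore a number 2 percentage points higher from compound 3 to compound 4 (within the scatter), inside the scatter. The estimate for compound 4 is 82%, ranging from 65% to 95%.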

Compound 4, a percentage reported as inhibition, at one concentration (the size of the read-out at that concentration, not a potency): 49%
Compound 4: the middle estimate sits 33 percentage points above what was measured, and the stated range ends above it.
By their numbers in this assay, from the lowest: compounds 4 and 1 (each within the scatter of the next); then compounds 3 and 2 (each within the scatter of the next).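

In this assay, chloro in place of methyl on an aromatic carbon of the core gives a number 31 percentage points lower from compound 3 to compound 4 (beyond the scatter), so with 3,5-dimethylphenyl on the sulfonyl sulfur this position is far from indifferent to the exchange. With chloro on the core, the sulfonyl aryl group also counts, giving a number 38 percentage points lower from compound 2 to compound 4 (beyond the scatter), whereas the change from phenyl gives a number 10 percentage points lower from compound 1 to compound 4 (within the scatter). No evidence here accounts for these results.

From the compounds shown here alone, whether the loss on going to chloro also holds with 3-methoxyphenyl or phenyl on the sulfonyl sulfur remains open. So does how fluoro or a nitrile would read at this core position.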